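A few compounds are considered here, and "the series" means these few. Any claim that something is new, unique, unknown or untested is made for them only; others in the source may bear on it.

Compound 1, whose structure is `O=C(O)c1cc(-n2c(-c3ccccc3)cc3c2CCCC3)ccc1O`, carries a carboxylic acid and a hydroxyl on its core. In a functional assay on the whole organism (strain Wistar) for inhibition, with Rattus norvegicus as the target, read by paw edema, with stated times of 30 min and 3 h, at a dose of 200 mg/kg by the oral route (on this read-out lower numbers stand for less inhibition and higher numbers for more inhibition at the one dose given (going by the name of the read-out)), compound 1 gives >= 60%, which is a limit of the assay rather than a number. This is the limit of >= 60% in this assay, at which 1 of the 3 values shown sits, so where compound 1 truly stands is known only as that limit.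

Two measured changes start from compound 1. Compound 2, with structure `O=C(O)c1cc(-n2c(-c3ccccc3)cc3c2CCCC3)cc(Cl)c1O`, gives 0% in this assay, and the step of a number at least 60 percentage points lower from compound 1 to compound 2 (beyond the scatter) came with chloro in place of hydrogen on an aromatic carbon. Compound 3, with structure `O=C(O)c1cc(-n2c(-c3cccs3)cc3c2CCCC3)ccc1O`, gives 30%, and the step of a number at least 30 percentage points lower from compound 1 to compound 3 (beyond the scatter) came with thiophen-2-yl in place of phenyl on an aromatic carbon.

Compound 4, with structure `COC1CCc2c(cc(-c3ccccc3)n2-c2ccc(O)c(C(=O)O)c2)C1`, differs from compound 1 by methoxy in place of hydrogen on a saturated ring carbon. Neither measured step touches a saturated ring carbon, so neither bears directly on this change; both merely show that changes to compound 1 so far have lowered inhibition. The step from compound 1 to compound 4 is therefore expected to be a number at least 10 percentage points lower from compound 1 to compound 4 (that floor lies within the scatter), a modest fall or none beyond the scatter. Compound 4 is estimated to give 50% in this assay, within 20% and 75%.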

Compound 4, a percentage reported as inhibition, in the whole organism at one dose (the size of the read-out at that dose, not a potency): 40%
The estimate for compound 4 lay 10 percentage points above the measured number; measured number inside the range.
By their numbers in this assay, from the lowest: compound 2; then compounds 3 and 4 (each within the scatter of the next). At a limit, above all of these: compound 1.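

In this assay, methoxy in place of hydrogen on a saturated ring carbon gave a number at least 20 percentage points lower from compound 1 to compound 4 (beyond the scatter), so the six-membered non-aromatic ring of carbon only, which neither earlier change had touched, is also a place where a substitution can lower the read-out. With this result, all three single changes shown from compound 1 lower the number, although the methoxy change does not remove the inhibition entirely, as compound 4 gives 40%. The true size of the step remains open because compound 1 stands at a limit and not at a number: the limit of >= 60% in this assay, at which 1 of the 4 values shown sits.

The compounds shown leave open whether the fall belongs to methoxy in particular or to any group on this saturated ring carbon, a question that a methyl, a hydroxyl or an amine at the same place would help to answer. They also leave open whether a longer chain ending in an ether oxygen would lower the number further or leave it within the usual scatter of compound 4.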